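Chain extension at the carbinol carbon of the naphthoquinone series

This account rests on a few compounds, and the source may have more. Where it says the series, first, only, none or still open, it means among the compounds named here.

Measured so far:
compound 1 `CC(O)C1=CC(=O)c2ccccc2C1=O` — 6400 nM
compound 2 `O=C1C=C(C(O)c2cccc(F)c2)C(=O)c2ccccc21` — 5500 nM

In a functional assay on WHCO1 cells (Homo sapiens) for cytotoxicity, read by MTT assay, with a stated time of 24 h (on this read-out higher numbers stand for weaker inhibition and lower numbers for stronger inhibition), compound 1 gives 6400 nM. Compound 2, which carries 3-fluorophenyl in place of methyl on the saturated chain carbon bound to the double-bonded ring carbon and the oxygen, gives 5500 nM; the step of a 1.2-fold lower number from compound 1 to compound 2 (0.07 log units; within the scatter) sits within the scatter, so the two numbers cannot be ordered.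

Compound 3 `O=C1C=C(C(O)CCc2ccccc2)C(=O)c2ccccc21` is not yet measured. It differs from compound 1 by benzyl in place of hydrogen on a saturated chain carbon, two bonds along the chain from a double-bonded ring carbon and an oxygen on a saturated carbon. Going by the values given here, the only measured step that bears on it is the one from compound 1 to compound 2, where a substantial change at the same saturated chain carbon left the read-out essentially unchanged. Nothing measured speaks to a change made two bonds further along the chain, so the expectation rests on that single neighbouring step and stays cautious.

The step from compound 1 to compound 3 in this assay is expected to be a 1.3-fold lower number from compound 1 to compound 3 (0.11 log units; within the scatter), that is, nothing beyond the scatter. Compound 3 is therefore estimated at 5000 nM, with a range from 2000 nM to 12000 nM.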

Compound 3, half-maximal inhibitory concentration: 4800 nM
Compound 3: middle estimate off by 1.0-fold (0.02 log units), on the high side, within the range that was stated.
By their numbers in this assay, from the lowest: compounds 3, 2 and 1 (each within the scatter of the next).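

In this assay, benzyl in place of hydrogen on a saturated chain carbon, two bonds along the chain from a double-bonded ring carbon and an oxygen on a saturated carbon, gives a 1.3-fold lower number from compound 1 to compound 3 (0.12 log units; within the scatter) and so does not take the read-out beyond the scatter. The earlier step concerned only the saturated chain carbon bound to the double-bonded ring carbon and the oxygen, whereas this one shows that a position further along the chain also accepts 7 heavy atoms, including one six-membered aromatic ring of carbon only, with no readable change. Across compounds 1, 2 and 3, none of the listed steps therefore separates one compound from another, and nothing in hand explains why the read-out stays put.

The compounds shown leave open whether any group at this position can move the number beyond the scatter, for example an amine or a carboxylic acid at the end of the chain, or a longer chain. They also leave open what happens when the hydroxyl on the saturated carbon gives way to a ketone or a methyl ether, with the rest of compound 3 kept unchanged.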